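Same atoms, new arrangement: from compound 3 to compound 4

A few compounds are considered here, and "the series" means these few. Any claim that something is new, unique, unknown or untested is made for them only; others in the source may bear on it.

Measured in an ADME assay on microsomes from liver (Mus musculus) for metabolic stability; a higher number here means that more of the compound is left, a lower number that less of the compound is left:
- compound 1 `C/C(=C/CN(C[C@H]1Cc2ccccc2CN1)[C@H]1CCCc2cccnc21)CN`: 2%
- compound 2 `N[C@H]1CC[C@H](CN(C[C@H]2Cc3ccccc3CN2)[C@H]2CCCc3cccnc32)CC1`: 44%
- compound 3 `C/C(CN(C[C@H]1Cc2ccccc2CN1)[C@H]1CCCc2cccnc21)=C(/F)CN`: 15%

Compound 3 stands in the middle of these three numbers, above compound 1 and below compound 2. The next structure, compound 4 `C/C(CN)=C(\F)CN(C[C@H]1Cc2ccccc2CN1)[C@H]1CCCc2cccnc21`, has the same atoms as compound 3, joined differently: 2-(aminomethyl)-1-fluoroprop-1-en-1-yl in place of 3-amino-2-fluoro-1-methylprop-1-en-1-yl on a saturated chain carbon bound to an amine nitrogen.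

Among the compounds with values here, no measured step is a rearrangement of this kind. The closest guide is the modest a number 13 percentage points higher from compound 1 to compound 3 (beyond the scatter), which also involves an open-chain group. The large a number 42 percentage points higher from compound 1 to compound 2 (beyond the scatter) and the modest a number 29 percentage points lower from compound 2 to compound 3 (beyond the scatter) both involve a ring, and compound 4 has none. In this assay, no change beyond the scatter is therefore expected: a number 3 percentage points lower from compound 3 to compound 4 (within the scatter).

For compound 4, the estimated value is 12%, with an expected range of 3% to 30%.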

Compound 4, percent of the compound remaining: 2%
Compound 4: the middle estimate sits 10 percentage points above what was measured; measured number below the stated range.
By their numbers in this assay, from the lowest: compounds 1 and 4 (each within the scatter of the next); then compound 3; then compound 2.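

In this assay, rearranging the same atoms in the open chain gives a number 13 percentage points lower from compound 3 to compound 4 (beyond the scatter) and so is not a neutral change at this position. With fluorine on the carbon bound to the chain, the gain seen with compound 3 is gone, since the result is no change at the digits printed from compound 1 to compound 4 (within the scatter) in this measurement. The open chain also falls well short of the ring, with a number 42 percentage points lower from compound 2 to compound 4 (beyond the scatter) for this swap. Nothing shown explains why the arrangement matters. From the compounds shown here alone, whether an open chain without a double bond, such as 4-aminobutyl, would come closer to compound 2 remains open.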